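A few compounds are considered here, and "the series" means these few. Any claim that something is new, unique, unknown or untested is made for them only; others in the source may bear on it.

Three compounds have so far been measured in an ADME assay on the whole organism with Oryza sativa as the target, tested at 1 uM; on this read-out lower numbers stand for a stronger effect and higher numbers for a weaker effect at the one concentration tested:

Compound 1 `CC(C)c1ccc(NC(=O)N[C@@H](C)c2ccccc2)cc1` gives 96%.
Compound 2 `C[C@H](NC(=O)Nc1ccc(C(C)(C)C)cc1)c1ccccc1` gives 88%.
Compound 3 `CCCCCCc1ccc(NC(=O)N[C@@H](C)c2ccccc2)cc1` gives 100%.

Compound 3 stands highest of these three numbers. Its distance from compound 1 is small, a number 4 percentage points higher from compound 1 to compound 3 (within the scatter), while its distance from compound 2 is larger, a number 12 percentage points higher from compound 2 to compound 3 (beyond the scatter). Both of those steps swap one group on the same aromatic carbon: isopropyl to hexyl in the first, tert-butyl to hexyl in the second, and in each case the hexyl compound came out with the higher number.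

The next compound, compound 4 `C[C@H](NC(=O)Nc1ccc(I)cc1)c1ccccc1`, changes that same aromatic carbon once more, this time in the other direction of size: iodo in place of hexyl on an aromatic carbon. The group that enters has one heavy atom where the group that leaves has six. Going by the values given here, on the numbers so far, going from hexyl to a smaller group at this position gave a lower number, once within the scatter and once beyond it. A step of about that size, downward, is therefore expected for compound 4, that is a number 12 percentage points lower from compound 3 to compound 4 (beyond the scatter). The estimate for compound 4 in this assay is 88%, with a range from 75% to 100%.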

Compound 4, a percentage reported as activity, at one concentration (the size of the read-out at that concentration, not a potency): 97%
Estimate against measurement, compound 4: 9 percentage points below, and the stated range covers the measured number.
By their numbers in this assay, from the lowest: compounds 2, 1, 4 and 3 (each within the scatter of the next, the first and the last beyond it).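

In this assay, replacing hexyl (6 heavy atoms) with iodo (1 heavy atom) gives a number 3 percentage points lower from compound 3 to compound 4 (within the scatter) and so shows that a large cut in heavy atoms at this aromatic carbon need not move the number beyond the scatter. Iodo also cannot be told apart from either branched group, with a number 1 percentage points higher from compound 1 to compound 4 (within the scatter) for isopropyl and a number 9 percentage points higher from compound 2 to compound 4 (within the scatter) for tert-butyl, so compound 4 sits within the scatter of all three earlier compounds and the tert-butyl to hexyl step remains the only one at this position that lies beyond it. Heavy-atom count therefore does not sort these four groups in any simple order, and nothing available explains the result.

As far as these compounds go, whether an amine or a carboxylic acid on this aromatic carbon would give a number clearly apart from these four remains open. Also open, from the compounds shown here alone, is how far a change elsewhere in the shared core would move the number, and whether the picture would hold at other concentrations, since each value comes from a single concentration.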